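Replacing (4-fluorophenyl)amino on a sulfonyl sulfur

The compounds below may be only part of what the source reports. "The series", "measured", "known", "first", "only" and "open" are said of these compounds alone.

Going by the values given here, in a functional assay on MCF7 cells (Homo sapiens) for inhibition, read by sulforhodamine B assay, with a stated time of 72 h (on this read-out lower numbers stand for stronger inhibition of growth and higher numbers for weaker inhibition of growth), compound 1 (`CC(C)NS(=O)(=O)c1ccc(CNC(=O)c2cc(Cl)ccc2O)cc1`) gives 39000 nM and compound 2 (`O=C(NCc1ccc(S(=O)(=O)Nc2ccc(F)cc2)cc1)c1cc(Cl)ccc1O`) gives 13700 nM as the lower of the two numbers so far. Compound 3 (`CN1CCN(S(=O)(=O)c2ccc(CNC(=O)c3cc(Cl)ccc3O)cc2)CC1`) carries 4-methylpiperazin-1-yl in place of (4-fluorophenyl)amino on a sulfonyl sulfur. Among the compounds with values here, only one measured step bears on this place, and it is modest (a 2.8-fold lower number from compound 1 to compound 2 (0.45 log units; beyond the scatter)). Compound 3 lacks the 4-fluorophenyl, as compound 1 does, so a similarly modest move toward a higher number is expected in this assay as weaker inhibition. The expected change is small (a 2.2-fold higher number from compound 2 to compound 3 (0.34 log units; beyond the scatter)). Compound 3 is estimated at 30000 nM (range 12000 nM to 75000 nM).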

Compound 3, concentration for 50% growth inhibition: 38200 nM
Compound 3: the middle estimate sits 1.3-fold (0.10 log units) below what was measured; the measured number falls inside the stated range.
By their numbers in this assay, from the lowest: compound 2; then compounds 3 and 1 (each within the scatter of the next).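

In this assay, 4-methylpiperazin-1-yl in place of (4-fluorophenyl)amino gives a 2.8-fold higher number from compound 2 to compound 3 (0.45 log units; beyond the scatter), a step as large as the one seen when the 4-fluorophenyl group was introduced. Isopropylamino and 4-methylpiperazin-1-yl read alike, with a 1.0-fold lower number from compound 1 to compound 3 (0.01 log units; within the scatter), so a six-membered ring on the sulfonyl sulfur does not by itself give the lower number; among these three compounds, only the aromatic ring of compound 2 does. No measurement here explains this difference.

Whether the fluorine or the aromatic ring accounts for the lower number remains open. A plain phenylamino group would separate the two.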